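This account rests on a few compounds, and the source may have more. Where it says the series, first, only, none or still open, it means among the compounds named here.

In an assay for activation of Adrenergic receptor alpha-1 (Rattus norvegicus) (on this read-out lower numbers stand for an effect already at smaller amounts and higher numbers for an effect only at larger amounts of compound), compound 2 `Clc1cccc2c1CC2CCCN1CCN(c2cccc3c2OCCO3)CC1` gives 1.25 mg/kg, the lowest of the two numbers in this assay. Compound 1 `c1ccc2c(c1)CC(CCCN1CCN(c3cccc4c3OCCO4)CC1)C2` gives 1.73 mg/kg, and the step of a 1.4-fold lower number from compound 1 to compound 2 (0.14 log units; within the scatter) exchanges the whole fused ring system. Compound 3 `c1ccc2c(c1)CCCCC2CCN1CCN(c2cccc3c2OCCO3)CC1` reaches only the limit > 2.5 mg/kg, which is not a number; it sits at the limit of > 2.5 mg/kg in this assay, at which 1 of the 3 values shown sits. Compound 4 `c1ccc2c(c1)CC2CCCN1CCN(c2cccc3c2OCCO3)CC1` differs from compound 2 by hydrogen in place of chloro on an aromatic carbon. For the measured compounds named here, no measured step isolates the chloro alone; the only step involving it, from compound 1 to compound 2, stayed within the scatter, so no shift beyond the scatter is expected in this assay. Compound 4 is therefore estimated at 1.5 mg/kg, between 0.7 mg/kg and 3.2 mg/kg, an expected step of a 1.2-fold higher number from compound 2 to compound 4 (0.08 log units; within the scatter).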

Compound 4, dose for half-maximal effect: 0.45 mg/kg
The estimate for compound 4 lay 3.3-fold (0.52 log units) above the measured number, outside the stated range (below it).
By their numbers in this assay, from the lowest: compound 4; then compounds 2 and 1 (each within the scatter of the next). At a limit, above all of these: compound 3.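

With the chloro gone and hydrogen on this aromatic carbon, ortho to a fused ring and meta to a fused ring, this assay shows a shift beyond the scatter, a 2.8-fold lower number from compound 2 to compound 4 (0.44 log units; beyond the scatter). For the compounds shown here, the chloro therefore matters at this position, which the earlier compounds did not reveal. Without it, the exchange of the ring group also reads beyond the scatter, a 3.8-fold lower number from compound 1 to compound 4 (0.58 log units; beyond the scatter), and nothing given here explains either shift. Open, going by these compounds, is whether fluoro or methoxy on this carbon would read like chloro or like hydrogen. Also open, on these data alone, is how a longer chain would read on the core of compound 4.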